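The source may hold more compounds than are shown below. What is called first, only, known or untested is meant among the compounds shown, and "the series" means these compounds.

Among the two compounds measured so far, compound 1 `COc1ccc(-c2nc(SCC(=O)c3sc(-c4ccccc4)nc3C)nc(N)c2C#N)cc1` shows the lower number: in a functional assay on U-87MG ATCC cells for antiproliferative activity against U-87 MG (Homo sapiens), read by MTT assay, with a stated time of 48 h, tested at 10 uM (on this read-out lower numbers stand for a stronger effect and higher numbers for a weaker effect at the one concentration tested), compound 1 gives 60.8%, while compound 2 `Cc1nc(-c2ccccc2)sc1C(=O)CSc1nc(N)c(C#N)c(-c2ccccc2)n1`, which has hydrogen in place of methoxy on an aromatic carbon, gives 93%. For the measured compounds named here, that single measured step, a number 32.2 percentage points higher from compound 1 to compound 2 (beyond the scatter), is large and lies beyond the scatter, and it is the only step available to judge the next change. Compound 3 `COc1ccc(-c2nc(C)c(C(=O)CSc3nc(N)c(C#N)c(-c4ccc(OC)cc4)n3)s2)cc1` keeps everything in compound 1 and adds a second methoxy: methoxy in place of hydrogen on an aromatic carbon. Going by the values given here, the place is a different ring from the one changed between compound 1 and compound 2, so the measured step bears on it only loosely, by showing that a methoxy on an aromatic carbon can shift this assay strongly. A step in the same direction as keeping the methoxy, that is toward a lower number, is expected but with wide uncertainty, and a number 8.8 percentage points lower from compound 1 to compound 3 (within the scatter) is the estimated step. Compound 3 is therefore expected to give about 52% in this assay, between 30% and 80%.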

Compound 3, a percentage reported as activity, at one concentration (the size of the read-out at that concentration, not a potency): 28.7%
Compound 3: middle estimate off by 23.3 percentage points, on the high side, outside the stated range (below it).
By their numbers in this assay, from the lowest: compound 3; then compound 1; then compound 2.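

In this assay, changing phenyl to 4-methoxyphenyl, with the methoxy para to a large group, gives a number 32.1 percentage points lower from compound 1 to compound 3 (beyond the scatter), so this ring responds strongly to a methoxy, which the earlier pair could not show. Removing the methoxy from the other ring gave a number 32.2 percentage points higher from compound 1 to compound 2 (beyond the scatter), so in these compounds a methoxy at either place goes with a lower number, and no compound shown goes against this. Nothing available explains why this change has so large an effect.

As far as these compounds go, it remains open whether methoxy itself matters here, or whether a hydroxyl, an amine or a longer ethoxy chain at the same place would give a similar number. From the compounds shown here alone, it is also open how a methoxy on this ring behaves when the other ring carries only hydrogen.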